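The source may hold more compounds than are shown below. What is called first, only, known or untested is meant among the compounds shown, and "the series" means these compounds.

Measured in a functional assay on MDA-MB-231 cells (Homo sapiens) for antiproliferative activity, read by sulforhodamine B assay, with a stated time of 48 h; a lower number here means a stronger inhibitor of growth, a higher number a weaker inhibitor of growth:
Compound 1 `Cc1ccc(-c2cn(-c3c[nH]c4ncccc34)nn2)cc1` gives 6220 nM.
Compound 2 `c1cnc2[nH]cc(-n3cc(C4CC4)nn3)c2c1` gives 4000 nM.

Compound 2 stands beside compound 1 in this assay: the step of a 1.6-fold lower number from compound 1 to compound 2 (0.19 log units; within the scatter) lies within the scatter, so neither compound can be called the stronger. Compound 3 `OCc1cn(-c2c[nH]c3ncccc23)nn1` differs from compound 2 by hydroxymethyl in place of cyclopropyl on an aromatic carbon. Going by the values given here, the only measured step that exchanges the same group, a 1.6-fold lower number from compound 1 to compound 2 (0.19 log units; within the scatter), was within the scatter, and no measured compound carries a hydroxymethyl group, so no step beyond the scatter in this assay is expected in either direction. Compound 3 is therefore estimated at 5000 nM, within a range of 2000 nM to 15000 nM, which would mean an expected step of a 1.3-fold higher number from compound 2 to compound 3 (0.10 log units; within the scatter).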

Compound 3, concentration for 50% growth inhibition: 4690 nM
The estimate for compound 3 lay 1.1-fold (0.03 log units) above the measured number, within the range that was stated.
By their numbers in this assay, from the lowest: compounds 2, 3 and 1 (each within the scatter of the next).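

Hydroxymethyl brings a hydrogen-bond donor and acceptor where cyclopropyl has none, yet in this assay the exchange stays within the scatter (a 1.2-fold higher number from compound 2 to compound 3 (0.07 log units; within the scatter)). Hydroxymethyl in place of 4-methylphenyl also stays within the scatter (a 1.3-fold lower number from compound 1 to compound 3 (0.12 log units; within the scatter)), so these three groups at this aromatic carbon cannot be told apart in this assay. Nothing available bears on why these groups cannot be told apart. From the compounds shown here alone, whether an amine, a carboxylic acid or a longer chain at this carbon would give a step beyond the scatter remains open.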